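The source may hold more compounds than are shown below. What is called first, only, known or untested is meant among the compounds shown, and "the series" means these compounds.

Series notes. In a physicochemical assay for solubility, at pH 6.5 (on this read-out lower numbers stand for lower solubility and higher numbers for higher solubility), compound 1 `CS(=O)(=O)c1cncc(-c2cnc3ccc(-c4cccc(S(=O)(=O)C5CC5)c4)nn23)c1` gives only a limit, < 5000 nM. Compound 2 `NC(=O)c1ccc(-c2cnc3ccc(-c4cccc(S(=O)(=O)C5CC5)c4)nn23)cc1` likewise gives only a limit in this assay, < 5000 nM. Compound 3 `CS(=O)(=O)c1ccc(-c2cnc3ccc(-c4cccc(S(=O)(=O)CCO)c4)nn23)cc1` gives a number in this assay, 8600 nM. Compound 2 therefore stands at the limit of < 5000 nM in this assay, at which 2 of the 3 values shown sit, without a number of its own. Going by the values given here, the single step measured in one place, a step that the two limits leave unreadable from compound 1 to compound 2, runs between two limits and its size cannot be read. Among the compounds with values here, compound 2 and compound 3 differ in two places, so no step is computed between them; their two values show one limit and one number.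

Compound 4 `C[S+]([O-])c1cccc(-c2ccc3ncc(-c4ccc(C(N)=O)cc4)n3n2)c1` is the next member. It differs from compound 2 by a group of 3 heavy atoms (1 carbon, 1 oxygen, 1 sulfur; no ring) in place of a group of 6 heavy atoms (3 carbon, 2 oxygen, 1 sulfur; one three-membered non-aromatic ring of carbon only), on an aromatic carbon. Within the data shown here, no measured step bears readably on this change: the only measured step, a step that the two limits leave unreadable from compound 1 to compound 2, touches a different group and is itself unreadable, and compound 3 carries other groups in two places. The expectation for compound 4 can rest only on the spread seen so far, two limits and one number a little past the limit. Compound 4 is expected to give about 6000 nM, between 2000 nM and 18000 nM, with a real chance that this assay again reports only the limit. This means an estimated step of an at least 1.2-fold higher number from compound 2 to compound 4 (0.07 log units; that floor lies within the scatter), not beyond the scatter.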

Compound 4, solubility: < 5000 nM
Compound 4 ended at the assay's limit; the forecaster's own chance of this, stated with the estimate: 45%; middle value at least 1.2-fold (0.07 log units) from the limit.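

In this assay, compound 2 and compound 4 both end at a limit and not at a number, so no new step can be read between them: the limit of < 5000 nM in this assay, at which 3 of the 4 values shown sit. Still open, going by these compounds, is whether this assay gives a number for either compound, and so how far cyclopropylsulfonyl and the group of 3 heavy atoms differ on this read-out.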